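Replacing phenyl with propyl in compound 3

The compounds below may be only part of what the source reports. "The series", "measured", "known", "first", "only" and "open" are said of these compounds alone.

Measured in an ADME assay on Caco-2 cells (Homo sapiens) for permeability, read by LC-MS, in the apical to basolateral direction, with a stated time of 60 min, at pH 6.5; on this read-out lower numbers stand for lower permeability and higher numbers for higher permeability:
- compound 1 `O=C(NCc1cc(Cl)ccc1-n1cnnn1)[C@@H]1CC=NN1C(=O)[C@H](O)c1ccccc1`: 7 10^-6 cm/s
- compound 2 `CC(C)(C)C[C@@H](O)C(=O)N1N=CC[C@H]1C(=O)NCc1cc(Cl)ccc1-n1cnnn1`: 24 10^-6 cm/s
- compound 3 `O=C(NCc1cc(Cl)ccc1-n1cnnn1)[C@@H]1CC=NN1C(=O)[C@H](O)Cc1ccccc1`: 11 10^-6 cm/s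

Compound 3 lies within the usual scatter of compound 1, and compound 2 stands clearly above both. Compound 4 `CCCC[C@@H](O)C(=O)N1N=CC[C@H]1C(=O)NCc1cc(Cl)ccc1-n1cnnn1` differs from compound 3 in one place: propyl in place of phenyl on a saturated chain carbon, two bonds along the chain from a carbonyl carbon and an oxygen on a saturated carbon. The closest evidence is a 2.2-fold lower number from compound 2 to compound 3 (0.34 log units; beyond the scatter), with phenyl in place of tert-butyl at that same place. Neopentyl in place of phenyl gave a 3.4-fold higher number from compound 1 to compound 2 (0.54 log units; beyond the scatter). Both are modest and rest on compound 2 alone, so only a small rise in this assay is expected. The expected step is a 1.7-fold higher number from compound 3 to compound 4 (0.24 log units; within the scatter). For compound 4 the estimate is 19 10^-6 cm/s, with an expected range of 10 10^-6 cm/s to 35 10^-6 cm/s.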

Compound 4, apparent permeability: 9.8 10^-6 cm/s
For compound 4 the middle estimate is 1.9-fold (0.29 log units) above the measured one, outside the stated range (below it).
By their numbers in this assay, from the lowest: compounds 1, 4 and 3 (each within the scatter of the next); then compound 2.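

In this assay, the open chain of compound 4 sits with the ring-bearing compounds (propyl for phenyl: a 1.1-fold lower number from compound 3 to compound 4 (0.05 log units; within the scatter); butyl for phenyl: a 1.4-fold higher number from compound 1 to compound 4 (0.15 log units; within the scatter)) but not with compound 2 (propyl for tert-butyl: a 2.4-fold lower number from compound 2 to compound 4 (0.39 log units; beyond the scatter)). Replacing the aromatic ring with an unbranched chain is therefore not enough to reach the number of compound 2, and among these four compounds only compound 2, with its tert-butyl end, stands apart. Nothing measured here says why. Still open, on these data alone, is how an isobutyl group, a longer chain such as hexyl, or a chain ending in an amine would read at this position.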